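The compounds below may be only part of what the source reports. "The series", "measured", "known", "first", "only" and "open" are said of these compounds alone.

Measured so far:
Compound 1 `COc1cccc(/C=C2\CCC/C(=C\c3ccccc3Cl)C2=O)c1OC`: 10300 nM
Compound 2 `COc1cccc(/C=C2\CCC/C(=C\c3ccc(Cl)cc3)C2=O)c1OC`: 11100 nM

In a functional assay on SW-620 cells (Homo sapiens) for cytotoxicity, read by MTT assay, with a stated time of 72 h (a higher number here means a weaker inhibitor, a lower number a stronger inhibitor), compound 2 stands, relative to compound 1, at a 1.1-fold higher number from compound 1 to compound 2 (0.03 log units; within the scatter). Compound 3 `COc1cccc(/C=C2\CCC/C(=C\c3cccc(Br)c3)C2=O)c1OC` differs from compound 2 by 3-bromophenyl in place of 4-chlorophenyl on a double-bonded chain carbon bound to a double-bonded ring carbon. The single measured step, a 1.1-fold higher number from compound 1 to compound 2 (0.03 log units; within the scatter), exchanged one chlorophenyl for another and stayed within the scatter; no measured step exchanges chlorine for bromine, so the shown data give no basis for a shift in this assay beyond the scatter. Compound 3 is therefore expected to give about 11000 nM, between 5500 nM and 22000 nM. That estimate means a step of a 1.0-fold lower number from compound 2 to compound 3 (0.00 log units; within the scatter), expected to lie within the scatter.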

Compound 3, half-maximal inhibitory concentration: 8800 nM
Compound 3: the middle estimate sits 1.3-fold (0.10 log units) above what was measured; the measured number falls inside the stated range.
By their numbers in this assay, from the lowest: compounds 3, 1 and 2 (each within the scatter of the next).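

Replacing 4-chlorophenyl with 3-bromophenyl gives a 1.3-fold lower number from compound 2 to compound 3 (0.10 log units; within the scatter) and replacing 2-chlorophenyl with 3-bromophenyl gives a 1.2-fold lower number from compound 1 to compound 3 (0.07 log units; within the scatter) in this assay so a bromine-bearing phenyl now joins the two chlorine-bearing ones at this place, with all three compounds lying within the scatter. Both steps change the halogen and its ring position together, and these three compounds cannot separate the two changes. No measurement shown explains why these numbers lie so close. All three compounds carry one halogen on this phenyl ring. From the compounds shown here alone, whether an amine or a carboxylic acid there would move the number beyond the scatter remains open.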